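Swapping the Benzyl for a Furan on the Indazole Nitrogen

The compounds below may be only part of what the source reports. "The series", "measured", "known", "first", "only" and "open" are said of these compounds alone.

Compound 2 `CCOC(=O)c1ccc(-c2nn(Cc3ccccc3OC)c3ccccc23)cc1` reaches only a limit in a functional assay on cells (Platelet, Homo sapiens) for inhibition (on this read-out lower numbers stand for stronger inhibition and higher numbers for weaker inhibition), giving > 10000 nM. Compound 1 `CCOC(=O)c1ccc(-c2nn(Cc3ccc(Cl)cc3)c3ccccc23)cc1` likewise stops at a limit in this assay, with > 10000 nM. The step from compound 1 to compound 2 is a step that the two limits leave unreadable from compound 1 to compound 2. Compound 3 `CCOC(=O)c1ccc(-c2nn(-c3ccco3)c3ccccc23)cc1` differs from compound 2 by furan-2-yl in place of 2-methoxybenzyl on an aromatic nitrogen. Among the measured compounds shown here, the only measured step gives no readable size, and both known values sit at the limit of > 10000 nM in this assay, at which 2 of the 2 values shown sit, so no shift beyond the scatter is expected in this assay. Compound 3 is estimated at 15000 nM, ranging from 3000 nM to 60000 nM, an expected step that the limit leaves unreadable from compound 2 to compound 3.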

Compound 3, half-maximal inhibitory concentration: > 10000 nM
Compound 3 gave a limit, no number; the forecaster's own chance of this, stated with the estimate: 80%; the middle value is on the limit's open side.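

Compound 3 also stops at a limit, > 10000 nM. No step among compound 1, compound 2 and compound 3 can be read, so all three remain unranked: the limit of > 10000 nM in this assay, at which 3 of the 3 values shown sit.

The compounds shown leave open whether any group on the aromatic nitrogen would give a measurable value.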